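The source may hold more compounds than are shown below. What is called first, only, known or untested is meant among the compounds shown, and "the series" means these compounds.

Measured compounds in an assay on isolated protein for inhibition of Nitric oxide synthase, inducible (Homo sapiens), with a stated time of 30 min, tested at 1 mM; on this read-out higher numbers stand for more inhibition at the one concentration tested (going by the name of the read-out) and lower numbers for less inhibition:
- compound 1, `COc1ccc(N)c(C2=NN(C(=O)C3CC3)CC2)c1`: 19.9%
- compound 2, `Nc1ccccc1C1=NN(C(=O)CCc2ccccc2)CC1`: 5.64%
- compound 3, `COc1ccc(N)c(C2=NN(C(=O)CCc3ccccc3)CC2)c1`: 21.2%

Compound 1 and compound 3 share a core; the difference between the cores of compound 1 and compound 2 is not broken down here. The change a number 1.3 percentage points higher from compound 1 to compound 3 (within the scatter) lies within the scatter. By contrast a number 15.6 percentage points higher from compound 2 to compound 3 (beyond the scatter) is a modest step, made by methoxy in place of hydrogen on an aromatic carbon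

Compound 4, `COc1cc(N)c(C2=NN(C(=O)C3CC3)CC2)cc1OC`, is not yet measured. It arises from compound 1 by methoxy in place of hydrogen on an aromatic carbon

This is the same kind of change as from compound 2 to compound 3, not the same: in compound 3 the entering methoxy stands meta to a large group and para to an amino group, whereas in compound 4 it stands ortho to a methoxy group, meta to an amino group and para to a large group. Because the change from compound 2 to compound 3 gave a number 15.6 percentage points higher from compound 2 to compound 3 (beyond the scatter), a smaller gain is expected here, a number 6.1 percentage points higher from compound 1 to compound 4 (within the scatter), given the different surroundings. Compound 4 is therefore estimated at 26%, between 8% and 44%, in this assay.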

Compound 4, a percentage reported as inhibition, at one concentration (the size of the read-out at that concentration, not a potency): 25.2%
Compound 4: the middle estimate sits 0.8 percentage points above what was measured; the measured number falls inside the stated range.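

In this assay, methoxy in place of hydrogen on an aromatic carbon gives a number 5.3 percentage points higher from compound 1 to compound 4 (within the scatter), a step that cannot be told from no change on its own. Set beside the step on the other core, it does not differ measurably: the same change on two cores in this assay, a number 15.6 percentage points higher (beyond the scatter) from compound 2 to compound 3 and a number 5.3 percentage points higher (within the scatter) from compound 1 to compound 4, 10.3 percentage points apart, within the scatter of two such steps. Among these compounds, this shows that the two results are compatible, but not that the change carries a fixed gain from core to core, as only one of the two steps lies beyond the scatter and the methoxy enters different surroundings in each.

The compounds shown leave open how a hydroxy group, a chlorine or a longer alkoxy chain would behave in place of the entering methoxy. They also leave open what an amine or a carboxylic acid on the carbonyl side chain would do.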